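The compounds below may be only part of what the source reports. "The series", "measured", "known", "first", "only" and "open" are said of these compounds alone.

Measured in a functional assay on BGC-823 cells (Homo sapiens) for cytotoxicity, read by MTT assay, with a stated time of 72 h; a lower number here means a stronger inhibitor, a higher number a weaker inhibitor:
compound 1 `C=C(C)[C@H]1CC[C@@](C)(O)[C@@H]1/C=C/C(C)=C/[C@@H]1C[C@@]23[C@H](OCCC[C@@H]2/C(=C(/C)C=O)CC[C@]3(C)O)O1`: > 10000 nM
compound 2 `C=C(C)[C@@H]1CC[C@](C)(O)[C@H]1/C=C/C(C)=C/[C@@H]1C[C@@]2([C@H](OC)O1)[C@H](CCCO)/C(=C(/C)C=O)CC[C@]2(C)O`: > 10000 nM

Compound 2 stands at > 10000 nM, which is a limit of the assay and not a number. The same holds for both measured compounds: the limit of > 10000 nM in this assay, at which 2 of the 2 values shown sit. Compound 3 `C=C(C)[C@@H]1CC[C@](C)(O)[C@H]1/C=C/C(C)=C/[C@@H]1C[C@@]2([C@H](OC)O1)[C@H](CCCO)/C(=C(\C)C=O)CC[C@]2(C)O` departs from compound 2 in configuration alone: the two compounds have the same atoms and bonds and differ only in configuration as drawn: 1 of 11 stereo elements differ; a double bond is drawn Z in compound 2 and E in compound 3. Going by the values given here, no measured step shows what such a change does. With compound 2 at > 10000 nM, a limit, no step beyond the scatter is expected in this assay, in either direction. The expected step is a number no higher from compound 2 to compound 3 (the limit leaves the size open). The estimate for compound 3 is 10000 nM, with an expected range of 4000 nM to 20000 nM.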

Compound 3, half-maximal inhibitory concentration: > 10000 nM
Compound 3: a limit, no number; the forecaster's own chance of this, stated with the estimate: 75%; the middle value sits exactly at the limit.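

Compound 2 and compound 3 both rest at a limit and not at a number, so no step can be read between them: the limit of > 10000 nM in this assay, at which 3 of the 3 values shown sit. From the compounds shown here alone, what drawing the double bond Z or E does to activity stays open.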